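Chloro to fluoro exchange, compound 1 to compound 3

The compounds below may be only part of what the source reports. "The series", "measured", "known", "first", "only" and "open" are said of these compounds alone.

Measured so far:
compound 1, `Nc1ccccc1NC(=O)c1ccc(NC(=O)NCc2ccc(Cl)nc2)cc1`: 2400 nM
compound 2, `Nc1ccccc1NC(=O)c1ccc(NC(=S)NCc2cncc(F)c2)cc1`: 13000 nM

In a functional assay on HepG2 cells (Homo sapiens) for cytotoxicity, read by MTT assay, with a stated time of 72 h (on this read-out lower numbers stand for stronger inhibition and higher numbers for weaker inhibition), compound 1 gives 2400 nM, the lowest of the two numbers shown; compound 2 gives 13000 nM, a gap beyond the scatter. Compound 3, `Nc1ccccc1NC(=O)c1ccc(NC(=O)NCc2ccc(F)nc2)cc1`, is not yet measured. It differs from compound 1 by fluoro in place of chloro on an aromatic carbon. Among the measured compounds shown here, no measured pair shows this change, so its size is unknown; in this assay a step within the scatter, or at most a small one toward a higher number, is expected. Compound 3 is therefore estimated at 3500 nM, range 1500 nM to 8000 nM. This estimate means an expected step of a 1.5-fold higher number from compound 1 to compound 3 (0.16 log units; within the scatter).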

Compound 3, half-maximal inhibitory concentration: 13000 nM
The estimate for compound 3 lay 3.7-fold (0.57 log units) below the measured number; the measured number lies above the stated range.
By their numbers in this assay, from the lowest: compound 1; then compounds 2 and 3 (each within the scatter of the next).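

Exchanging 6-chloropyridin-3-yl for 6-fluoropyridin-3-yl gives a 5.4-fold higher number from compound 1 to compound 3 (0.73 log units; beyond the scatter) in this assay. This first single-place comparison in the series shows that the read-out is sensitive to which halogen sits on this aromatic carbon, and that chloro is the better of the two here. No available data explain the step. Still open, as far as these compounds go, is how hydrogen, a methyl group or an amine at the same carbon would read. Also open, from the compounds shown here alone, is whether this exchange gives a step of similar size elsewhere.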